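The source may report more compounds than this note shows. Statements on the series, on what has been measured and on what is new or still open speak of the compounds shown alone.

Compound 1, `COc1cc(N)c(Cl)cc1NC(=O)C1CCN(CC2CC2)CC1`, in a functional assay on the whole organism for antagonist activity, with Mus musculus as the target (a higher number here means that more compound is needed for the effect, a lower number that less compound is needed), gives > 10 mg/kg, which is a limit of the assay.
Compound 2, `CCCCN1CCC(C(=O)Nc2cc(Cl)c(N)cc2OC)CC1`, in this assay gives > 10 mg/kg, likewise a limit.

The step that the two limits leave unreadable from compound 1 to compound 2 cannot be read, so compound 2 stands only at a limit, shared by both measured compounds (the limit of > 10 mg/kg in this assay, at which 2 of the 2 values shown sit). Compound 3, `COc1cc(N)c(Cl)cc1NC(=O)C1CCN(Cc2cccc(Cl)c2)CC1`, carries 3-chlorophenyl in place of propyl on a saturated chain carbon bound to an amine nitrogen in a ring. Going by the values given here, no measured step bears on this change, and no direction in this assay can be expected from the measured compounds. Compound 3 is therefore estimated at 10 mg/kg, between 2 mg/kg and 30 mg/kg, an expected step of a number no higher from compound 2 to compound 3 (the limit leaves the size open).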

Compound 3, dose for half-maximal effect: > 4 mg/kg
Compound 3 gave a limit, no number; the forecaster's own chance of this, stated with the estimate: 60%; the middle value lies beyond the limit too.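

Compound 3 in this assay gives > 4 mg/kg, a limit. Going by these compounds alone, compound 1 and compound 2 also stand at limits, so no step to compound 3 can be read. The compounds shown leave open whether exchanging cyclopropyl, propyl and 3-chlorophenyl changes the dose needed.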